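Methyl on the saturated ring of compound 2

The source may hold more compounds than are shown below. What is called first, only, known or untested is meant among the compounds shown, and "the series" means these compounds.

Measured so far:
compound 1 `C[C@@H]1CCCN1c1c(C#N)c2c(N)nc(Nc3ccn(C)n3)cc2n1C` — 13 nM
compound 2 `Cn1c(N2CCCC2)c(C#N)c2c(N)ncnc21` — 125 nM
compound 3 `Cn1c(NCc2ccccc2F)c(C#N)c2c(N)ncnc21` — 120 nM

In an assay on isolated protein for binding affinity to Leucine-rich repeat serine/threonine-protein kinase 2 variant G2019S (Homo sapiens), read by TR-FRET and LanthaScreen, with a stated time of 2 h (a lower number here means a stronger inhibitor, a higher number a weaker inhibitor), compound 2 gives 125 nM, the highest of the three numbers. Compound 3 gives 120 nM, which lies within the scatter of compound 2, so no order between the two can be read. Compound 1 gives 13 nM, a gap to compound 2 that lies beyond the scatter; compound 1 differs from compound 2 in more than one place, so this gap is not assigned to any single change.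

The next compound is compound 4 `C[C@H]1CCCN1c1c(C#N)c2c(N)ncnc2n1C`, which is to be measured in this assay. It differs from compound 2 as follows: methyl in place of hydrogen on a saturated ring carbon The methyl sits on a saturated ring carbon of the five-membered non-aromatic ring with one nitrogen, next to the ring nitrogen and next to the ring atom that bears a large group; cut one bond further out, the change reads pyrrolidin-1-yl to 2-methylpyrrolidin-1-yl.

Within the data shown here, no step between measured compounds isolates this change. Compound 1 carries the same 2-methylpyrrolidin-1-yl group together with other differences, and its number is lower than that of compound 2, so a modest move toward stronger binding is expected for compound 4, with a step of a 2.5-fold lower number from compound 2 to compound 4 (0.40 log units; beyond the scatter) estimated. Compound 4 is expected to give about 50 nM, within 18 nM to 140 nM.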

Compound 4, inhibition constant: 212 nM
For compound 4 the middle estimate is 4.2-fold (0.63 log units) below the measured one; measured number outside the range, above it.
By their numbers in this assay, from the lowest: compound 1; then compounds 3, 2 and 4 (each within the scatter of the next).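

In this assay, among these compounds, a 1.7-fold higher number from compound 2 to compound 4 (0.23 log units; within the scatter) is the first step that isolates methyl in place of hydrogen on a saturated ring carbon, and it shows no readable shift in binding on going from pyrrolidin-1-yl to 2-methylpyrrolidin-1-yl on this core. Among the compounds shown here, the 2-methylpyrrolidin-1-yl group shared with compound 1, at 13 nM, therefore gains no support from this step as the source of that compound's low number, which stays unassigned to any single change. No measurement at hand bears on why this methyl leaves the number within the scatter.

Still open, on these data alone, is whether ethyl or hydroxymethyl on the same saturated ring carbon would read as the methyl does, and whether the methyl step would read the same on the core of compound 1. The methyl-bearing carbon is also drawn with the opposite configuration in compound 1 and compound 4, so the part played by that configuration remains unresolved in this series.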